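Series notes: substituent swap on the aryl ring, compound 3 to 4

The source may report more compounds than this note shows. Statements on the series, on what has been measured and on what is new or still open speak of the compounds shown alone.

Measured so far in a functional assay on HepG2 cells (Homo sapiens) for antiproliferative activity, read by MTT assay, with a stated time of 48 h; on this read-out higher numbers stand for weaker inhibition and lower numbers for stronger inhibition:
Compound 1 `Nc1nc(N2CCCC2)sc1C(=O)/C=C/c1ccc([N+](=O)[O-])cc1` gives 23.5 ug/mL.
Compound 2 `Nc1nc(N2CCCCC2)sc1C(=O)/C=C/c1ccccc1` gives 16.6 ug/mL.
Compound 3 `Nc1nc(N2CCCCC2)sc1C(=O)/C=C/c1ccc(Br)cc1` gives 17.4 ug/mL.

Compound 3 stands second highest of the three numbers. For the measured compounds named here, its nearest neighbour is compound 2, and the only single-point step in the set, a 1.0-fold higher number from compound 2 to compound 3 (0.02 log units; within the scatter), shows that putting bromo on the aryl ring left the read-out unchanged. Going by the values given here, compound 1 is the furthest from compound 3, yet that gap is also within the scatter, and compound 1 differs from compound 3 in two places, so no step is assigned to it.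

The next compound, compound 4 `Nc1nc(N2CCCCC2)sc1C(=O)/C=C/c1ccc([N+](=O)[O-])cc1`, carries nitro in place of bromo on an aromatic carbon. Among the compounds with values here, the one step that bears on this position, the bromo-for-hydrogen exchange from compound 2 to compound 3, was flat, so a substituent change at this carbon has so far not moved the number. Compound 1, which carries the same nitro group but differs elsewhere, gives 23.5 ug/mL, which lies within the scatter of the others. The expected step is therefore a 1.1-fold higher number from compound 3 to compound 4 (0.04 log units; within the scatter), that is, none beyond the scatter. Compound 4 is accordingly estimated at 19 ug/mL, with a range from 9 ug/mL to 40 ug/mL.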

Compound 4, half-maximal inhibitory concentration: 15.4 ug/mL
Estimate against measurement, compound 4: 1.2-fold (0.09 log units) above; the range from low to high includes it.
By their numbers in this assay, from the lowest: compounds 4, 2, 3 and 1 (each within the scatter of the next).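

In this assay, nitro in place of bromo on the aromatic carbon para to a large group gives a second substituent change at this position that leaves the number within the scatter (a 1.1-fold lower number from compound 3 to compound 4 (0.05 log units; within the scatter)), and the comparison with the unsubstituted ring reads the same (a 1.1-fold lower number from compound 2 to compound 4 (0.03 log units; within the scatter)). Hydrogen, bromo and nitro at this carbon therefore cannot be told apart on the piperidin-1-yl compounds, whereas the earlier compounds offered only the bromo-for-hydrogen comparison. For the compounds shown here, compound 4 also gives the first comparison in one place at the other substituted site, and with nitro held constant, piperidin-1-yl in place of pyrrolidin-1-yl stays within the scatter too (a 1.5-fold lower number from compound 1 to compound 4 (0.18 log units; within the scatter)), although no evidence at hand bears on why these numbers stay together.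

It remains open whether an amine or a carboxylic acid on the aryl ring would move the number beyond the scatter, as the compounds shown carry only hydrogen, bromo or nitro there. Also open is whether a morpholine ring in place of piperidin-1-yl would separate from the compounds shown, and whether the flat reading at the aryl position holds with pyrrolidin-1-yl.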